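Fluoro for hydroxy on the pendant phenyl

This account rests on a few compounds, and the source may have more. Where it says the series, first, only, none or still open, it means among the compounds named here.

In a functional assay on SGC-7901 cells (Homo sapiens) for antiproliferative activity, read by MTT assay, with a stated time of 72 h (on this read-out higher numbers stand for weaker inhibition and lower numbers for stronger inhibition), compound 1 `COc1ccc(-c2ccc3ncn(-c4cc(OC)c(OC)c(OC)c4)c3c2)cc1` gives 82 nM. Compound 2 `COc1cc(-n2cnc3ccc(-c4ccc(O)cc4)cc32)cc(OC)c1OC` returns only a limit, > 10000 nM, and so stands at the limit of > 10000 nM in this assay, at which 1 of the 2 values shown sits. Within the data shown here, the one measured step, an at least 120-fold higher number from compound 1 to compound 2 (2.08 log units; beyond the scatter), is the relevant one, as compound 3 `COc1cc(-n2cnc3ccc(-c4ccc(F)cc4)cc32)cc(OC)c1OC` again takes the hydroxy away: fluoro in place of hydroxy on an aromatic carbon. A move back toward lower numbers is therefore expected, an at least 40-fold lower number from compound 2 to compound 3 (1.60 log units; beyond the scatter), though compound 2 is known only as a limit and the size is uncertain. Compound 3 is estimated at 250 nM in this assay, with a range of 40 nM to 3000 nM.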

Compound 3, half-maximal inhibitory concentration: 3500 nM
Compound 3: the middle estimate sits 14-fold (1.15 log units) below what was measured; the whole stated range lies below it.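

In this assay, replacing the hydroxy recovers only part of what was lost: an at least 2.8-fold lower number from compound 2 to compound 3 (0.45 log units; beyond the scatter). The 4-fluorophenyl does not match the 4-methoxyphenyl, with a 43-fold higher number from compound 1 to compound 3 (1.63 log units; beyond the scatter), so among these three compounds, lacking the hydroxy is not enough to reach the level of compound 1. The true size of the first step stays unknown because compound 2 is known only as a limit: the limit of > 10000 nM in this assay, at which 1 of the 3 values shown sits.

On these data alone, whether a methyl, a chloro or an amine on the same aromatic carbon would sit nearer compound 1 or compound 3 remains open. As far as these compounds go, whether the oxygen of the methoxy matters, as opposed to its methyl, also remains open.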